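This account rests on a few compounds, and the source may have more. Where it says the series, first, only, none or still open, it means among the compounds named here.

In an assay on isolated protein for inhibition of Trypsin (Homo sapiens) (a higher number here means a weaker inhibitor, a lower number a stronger inhibitor), compound 1 `Cc1nn(-c2cccc(CN)c2)c2c(F)c(-c3ccc(N4CCCCC4=O)cc3)ccc12` gives 1900 nM. Compound 2 `Cc1nn(-c2cccc(CN)c2)c2cc(-c3ccc(N4CCCCC4=O)cc3)ccc12` reaches only a limit of this assay, > 10000 nM. Compound 3 `NC(=O)c1nn(-c2ccc3onc(N)c3c2)c2c(F)c(-c3ccc(N4CCCCC4=O)cc3F)ccc12` likewise returns only a limit, > 10000 nM. Compound 3 thus stands at the limit of > 10000 nM in this assay, at which 2 of the 3 values shown sit, with no number of its own. Among the measured compounds shown here, the single measured step, an at least 5.2-fold higher number from compound 1 to compound 2 (0.72 log units; beyond the scatter), concerns a different part of the shared core and does not bear on the present change. Compound 4 `CN(C)CCN(c1ccccc1)c1ccc(-c2ccc3c(C(N)=O)nn(-c4ccc5onc(N)c5c4)c3c2F)c(F)c1` differs from compound 3 by (2-(dimethylamino)ethyl)(phenyl)amino in place of 2-oxopiperidin-1-yl on an aromatic carbon. For the measured compounds named here, no measured step covers this replacement, so no size or direction beyond the scatter can be derived in this assay, and the estimate for compound 4 is 15000 nM, expected to lie between 4000 nM and 50000 nM. The expected step is therefore a step that the limit leaves unreadable from compound 3 to compound 4, with a limit again the most likely outcome.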

Compound 4, inhibition constant: > 10000 nM
Compound 4 gave a limit, no number (the forecaster's own chance of this, stated with the estimate: 70%); the middle value lies beyond the limit too.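

Compound 4, like compound 3, returns only a limit, so no step between them can be read: the limit of > 10000 nM in this assay, at which 3 of the 4 values shown sit.

The compounds shown leave open whether (2-(dimethylamino)ethyl)(phenyl)amino and 2-oxopiperidin-1-yl differ at all, since neither compound has a number of its own.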